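Methoxy for (trifluoromethyl)sulfanyl on the aryl isoxazole

The source may report more compounds than this note shows. Statements on the series, on what has been measured and on what is new or still open speak of the compounds shown alone.

Compound 3 `FC(F)(F)Sc1ccc(-c2cc(CN(c3ncccn3)c3nc4ccccc4s3)on2)cc1` gives 17200 nM in a functional assay on MCF7 cells (Homo sapiens) for antiproliferative activity, read by MTT assay; on this read-out higher numbers stand for weaker inhibition and lower numbers for stronger inhibition. Compound 1 `COc1ccc2nc(N(Cc3cc(-c4ccc(OC(F)(F)F)cc4)no3)c3nc4ccc(F)cc4s3)sc2c1` gives 17400 nM in this assay, a number within the scatter of compound 3; compound 2 `COc1ccc2nc(N(Cc3cc(-c4ccc(Br)cc4)no3)c3nc4ccc(F)cc4s3)sc2c1` gives 41200 nM in this assay, which lies beyond the scatter above compound 3. Within the data shown here, compounds 1 and 2 share a core that is not that of compound 3, and the single measured step on that core, bromo in place of trifluoromethoxy at the same position of the phenyl ring, reads a 2.4-fold higher number from compound 1 to compound 2 (0.37 log units; beyond the scatter).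

Compound 4 `COc1ccc(-c2cc(CN(c3ncccn3)c3nc4ccccc4s3)on2)cc1` differs from compound 3 by methoxy in place of (trifluoromethyl)sulfanyl on an aromatic carbon, para to a large group. Among the measured compounds shown here, the only step that bears on this change is a 2.4-fold higher number from compound 1 to compound 2 (0.37 log units; beyond the scatter), which shows that exchanging the group at this position moves the number modestly; no step on the core of compound 3 itself is available. A modest step toward a higher number is therefore expected, a 1.7-fold higher number from compound 3 to compound 4 (0.24 log units; within the scatter). Compound 4 is estimated at 30000 nM, with a range from 12000 nM to 80000 nM.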

Compound 4, half-maximal inhibitory concentration: 30700 nM
Estimate against measurement, compound 4: 1.0-fold (0.01 log units) below; the range from low to high includes it.
By their numbers in this assay, from the lowest: compounds 3, 1, 4 and 2 (each within the scatter of the next, the first and the last beyond it).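

On the core of compound 3, the first step measured there at this position reads a 1.8-fold higher number from compound 3 to compound 4 (0.25 log units; within the scatter) in this assay. Replacing 4-((trifluoromethyl)sulfanyl)phenyl with 4-methoxyphenyl therefore gives no separable difference in this assay, even though the fluorine and sulfur atoms leave with the exchange. The step on the core of compound 1, a 2.4-fold higher number from compound 1 to compound 2 (0.37 log units; beyond the scatter), lies beyond the scatter, but it involves another pair of groups on another core, so the contrast cannot be assigned to either the core or the groups. Nothing at hand gives a cause for this result.

On these data alone, it remains open whether an amine or a carboxylic acid on this aromatic carbon would give a step beyond the scatter. Also open, as far as these compounds go, is whether methoxy would read the same way on the core of compound 1.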